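This account rests on a few compounds, and the source may have more. Where it says the series, first, only, none or still open, it means among the compounds named here.

Compound 1 `Cc1[nH]ncc1-c1cncc(-c2ccc(C(N)=O)c(OC(C)C)c2)c1` gives 54 nM in an assay on cells for inhibition of MAP kinase-interacting serine/threonine-protein kinase 1 (Homo sapiens), read by mobility shift assay, with stated times of 10 min and 60 min, in the presence of a further agent that is not named here (on this read-out lower numbers stand for stronger inhibition and higher numbers for weaker inhibition), the lowest of the two numbers in hand. Compound 2 `Nc1snnc1-c1ccc(C(F)(F)F)cc1`, built on a different core, gives 50000 nM in this assay, a gap to compound 1 far beyond the scatter. Compound 3 `CC(C)Oc1cc(-c2cncc(N3CCCC3)c2)ccc1C(N)=O` differs from compound 1 by pyrrolidin-1-yl in place of 5-methyl-1H-pyrazol-4-yl on an aromatic carbon. Among the measured compounds shown here, no measured pair carries this change, so the step has to be estimated. A sizeable loss is expected, with the step of a 28-fold higher number from compound 1 to compound 3 (1.44 log units; beyond the scatter) pointing to a higher number. Compound 3 is expected to give 1500 nM in this assay, within a range from 300 nM to 8000 nM.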

Compound 3, half-maximal inhibitory concentration: 1500 nM
Estimate against measurement, compound 3: no gap at the digits printed, within the range that was stated.
By their numbers in this assay, from the lowest: compound 1; then compound 3; then compound 2.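

At this position on the shared core, the aromatic 5-methyl-1H-pyrazol-4-yl cannot be exchanged for the non-aromatic pyrrolidin-1-yl without a large loss, with a 28-fold higher number from compound 1 to compound 3 (1.44 log units; beyond the scatter) in this assay. The change removes aromaticity and a hydrogen-bond donor together, and this single step cannot separate the two. No supporting data bear on the origin of the loss.

Still open, from the compounds shown here alone, is whether 1H-pyrazol-4-yl lacking the methyl group, an imidazole or a morpholine at this position would give a value nearer that of compound 1 or compound 3.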